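Working notes on three measured analogues and compound 4

A few compounds are considered here, and "the series" means these few. Any claim that something is new, unique, unknown or untested is made for them only; others in the source may bear on it.

Measured so far:
compound 1 `O=C(CSCc1ccco1)N1N=C(c2cc3ccccc3oc2=O)C[C@@H]1c1ccccc1C(F)(F)F`: 10300 nM
compound 2 `O=C(CSc1ccc(Br)cc1)N1N=C(c2cc3ccccc3oc2=O)C[C@@H]1c1ccccc1C(F)(F)F`: 14700 nM
compound 3 `O=C(CSc1ccc(Br)cc1)N1N=C(c2cc3ccccc3oc2=O)C[C@@H]1c1ccc(C(F)(F)F)cc1`: 12100 nM

All three numbers come from a functional assay on SGC-7901 cells (Homo sapiens) for cytotoxicity, read by MTT assay, with a stated time of 48 h; a lower number here means a stronger inhibitor, a higher number a weaker inhibitor. In this assay compound 3 holds the second highest number of the three; its step of a 1.2-fold lower number from compound 2 to compound 3 (0.08 log units; within the scatter) is within the scatter, and its value against compound 1 also shows no difference beyond the scatter. The three numbers are therefore indistinguishable.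

Compound 4 `O=C(CSCc1ccco1)N1N=C(c2cc3ccccc3oc2=O)C[C@@H]1c1ccc(C(F)(F)F)cc1` differs from compound 3 in one place: (furan-2-yl)methyl in place of 4-bromophenyl on a sulfur. Among the compounds with values here, the only measured step bearing on this is the same exchange in the opposite direction, a 1.4-fold higher number from compound 1 to compound 2 (0.15 log units; within the scatter), which stayed within the scatter. Reversing it gives no reason to expect a step beyond the scatter; at most a slight drop in number is expected, a 1.3-fold lower number from compound 3 to compound 4 (0.11 log units; within the scatter). Compound 4 is therefore estimated at 9500 nM in this assay, with a range from 5000 nM to 18000 nM.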

Compound 4, half-maximal inhibitory concentration: 9740 nM
For compound 4 the middle estimate is 1.0-fold (0.01 log units) below the measured one; low and high end bracket the measured number.
By their numbers in this assay, from the lowest: compounds 4, 1, 3 and 2 (each within the scatter of the next).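

In this assay, the exchange between 4-bromophenyl and (furan-2-yl)methyl on a sulfur can now be read on two cores, with a 1.2-fold lower number from compound 3 to compound 4 (0.09 log units; within the scatter), and neither step lies beyond the scatter: the same change on two cores in this assay, a 1.4-fold higher number (0.15 log units; within the scatter) from compound 1 to compound 2 and a 1.2-fold higher number (0.09 log units; within the scatter) from compound 4 to compound 3, 1.1-fold (0.06 log units) apart, within the scatter of two such steps. The exchange of 2-(trifluoromethyl)phenyl for 4-(trifluoromethyl)phenyl on a saturated ring carbon can also be read twice, with a 1.1-fold lower number from compound 1 to compound 4 (0.02 log units; within the scatter): the same change on two cores in this assay, a 1.2-fold lower number (0.08 log units; within the scatter) from compound 2 to compound 3 and a 1.1-fold lower number (0.02 log units; within the scatter) from compound 1 to compound 4, 1.1-fold (0.06 log units) apart, within the scatter of two such steps. Across compounds 1 to 4, neither change gives a step beyond the scatter, and no compound goes against this.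

As far as these compounds go, it remains open whether an amine or a carboxylic acid on a longer chain at the sulfur would give a step beyond the scatter.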